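This account rests on a few compounds, and the source may have more. Where it says the series, first, only, none or still open, it means among the compounds named here.

Measured compounds in the series:

compound 1, `C=CCCCCCCCC#CC#CC(O)CC(C)=O` — in a functional assay on HCT-15 cells (Homo sapiens) for cytotoxicity (a higher number here means that more compound is needed for the effect, a lower number that less compound is needed), compound 1 gives 4.18 ug/mL
compound 2, `CCCCCCCC#CC#CC(O)CC(C)=O` — in this assay compound 2 gives 3.73 ug/mL
compound 3, `C=CCCCCCCCC#CC#CCOCC(=O)OC` — in this assay compound 3 reaches only a limit of the assay, > 30 ug/mL, not a number

Compound 1 and compound 2 share one core and differ by a single change, (hydrogen in place of vinyl on a saturated chain carbon, seven bonds along the chain from a triple-bonded carbon). The step that this change made is a 1.1-fold lower number from compound 1 to compound 2 (0.05 log units; within the scatter), so the two values cannot be told apart within this assay.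

Compound 3 differs from compound 1 in more than one place; the difference between the two cores is not broken down here. Compound 3 stands at the limit of > 30 ug/mL in this assay, at which 1 of the 3 values shown sits.

Compound 4, `CCCCCCCC#CC#CCOCC(=O)OC`, has not yet been measured in this assay. It is related to compound 3 by hydrogen in place of vinyl on a saturated chain carbon, seven bonds along the chain from a triple-bonded carbon, the same change at the same place, word for word, as the change from compound 1 to compound 2.

The expectation for compound 4 rests on two things: the measured step of a 1.1-fold lower number from compound 1 to compound 2 (0.05 log units; within the scatter), which was within the scatter, and the limit at which compound 3 sits, (the limit of > 30 ug/mL in this assay, at which 1 of the 3 values shown sits). The step from compound 3 to compound 4 is therefore expected to be about a step that the limit leaves unreadable from compound 3 to compound 4, that is, no real shift. For compound 4 the estimate is 40 ug/mL, with a range from 20 ug/mL to 100 ug/mL, and a value that is again only a limit of the assay is considered the most likely outcome for compound 4.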

Compound 4, concentration for half-maximal effect: 25.6 ug/mL
For compound 4 the middle estimate is 1.6-fold (0.19 log units) above the measured one; low and high end bracket the measured number.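

Replacing vinyl with hydrogen on a saturated chain carbon, seven bonds along the chain from a triple-bonded carbon, gives in this assay an at least 1.1-fold lower number from compound 3 to compound 4 (0.06 log units; that floor lies within the scatter). Set beside the earlier step, the same change reads as follows on the two cores: the same change on two cores in this assay, a 1.1-fold lower number (0.05 log units; within the scatter) from compound 1 to compound 2 and an at least 1.1-fold lower number (0.06 log units; that floor lies within the scatter) from compound 3 to compound 4; the limit leaves it open whether they differ Nothing here speaks against the change carrying over from one core to the other without a real shift, yet an equal step on both cores is not shown: compound 3 has only a limit of the assay, > 30 ug/mL, and not a number.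

From the compounds shown here alone, the core of compound 1 and the core of compound 3 differ in more than one place, and which of those differences matters for the read-out stays open. Also open, going by these compounds, is how a longer chain, an amine or a carboxylic acid on either core would read in this assay.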